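Hydroxy on the shared core and a swapped para group

A few compounds are considered here, and "the series" means these few. Any claim that something is new, unique, unknown or untested is made for them only; others in the source may bear on it.

Measured compounds:
Compound 1, `COc1ccc(-c2ccc(-c3ccc(-c4nc5ccccc5[nH]4)cc3)cc2)cc1`, 45200 nM
Compound 2, `CN(C)c1ccc(-c2ccc(-c3ccc(-c4nc5ccccc5[nH]4)cc3)cc2)cc1`, 100000 nM
Compound 3, `COc1ccc(-c2ccc(-c3ccc(-c4nc5c(O)cccc5[nH]4)cc3)cc2)cc1`, 1630 nM

All three were tested in a functional assay on COLO 205 cells (Homo sapiens) for inhibition, read by sulforhodamine B assay; a lower number here means a stronger inhibitor of growth, a higher number a weaker inhibitor of growth. Compound 1 gives 45200 nM, and its dimethylamino analogue, compound 2, gives 100000 nM; the change between them is dimethylamino in place of methoxy on an aromatic carbon, and it produced a 2.2-fold higher number from compound 1 to compound 2 (0.34 log units; beyond the scatter). Compound 3 differs from compound 1 at the core: hydroxy in place of hydrogen on an aromatic carbon, a change that brought a 28-fold lower number from compound 1 to compound 3 (1.44 log units; beyond the scatter), so that compound 3, at 1630 nM, stands lowest of the three.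

Compound 4, `CN(C)c1ccc(-c2ccc(-c3ccc(-c4nc5c(O)cccc5[nH]4)cc3)cc2)cc1`, has not yet been measured. It relates to compound 3 as compound 2 relates to compound 1: the difference is dimethylamino in place of methoxy on an aromatic carbon, the same change in the same kind of place. For the measured compounds named here, on the hydroxy-bearing core this exchange has not been observed, so its size there is unknown, and the only guide is the earlier pair. From compound 3 to compound 4 a step of a 2.2-fold higher number from compound 3 to compound 4 (0.34 log units; beyond the scatter) is expected, because a 2.2-fold higher number from compound 1 to compound 2 (0.34 log units; beyond the scatter) was seen for that exchange on the unsubstituted core. For compound 4 in this assay a value near 3600 nM is estimated, between 1500 nM and 9000 nM.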

Compound 4, concentration for 50% growth inhibition: 6320 nM
For compound 4 the middle estimate is 1.8-fold (0.24 log units) below the measured one; the range from low to high includes it.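

In this assay, dimethylamino in place of methoxy gave a 3.9-fold higher number from compound 3 to compound 4 (0.59 log units; beyond the scatter), and the exchange carried over from one core to the other without a difference that can be told from the scatter: the same change on two cores in this assay, a 2.2-fold higher number (0.34 log units; beyond the scatter) from compound 1 to compound 2 and a 3.9-fold higher number (0.59 log units; beyond the scatter) from compound 3 to compound 4, 1.8-fold (0.24 log units) apart, within the scatter of two such steps
The hydroxy change held in the same way when read on the dimethylamino side, where it gave a 16-fold lower number from compound 2 to compound 4 (1.20 log units; beyond the scatter), so the large gain from hydroxy was kept with either para group: the same change on two cores in this assay, a 28-fold lower number (1.44 log units; beyond the scatter) from compound 1 to compound 3 and a 16-fold lower number (1.20 log units; beyond the scatter) from compound 2 to compound 4, 1.8-fold (0.24 log units) apart, within the scatter of two such steps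
This shows that each change behaved alike on the two backgrounds available here, but it rests on a single pair of steps for each change and does not show that either step would keep its size on any other core.

The compounds shown leave open whether a different group on that aromatic carbon, such as a primary amine or a carboxylic acid, would fit the same picture. They also leave open whether another group in place of the hydroxy on the core, such as an amine or a methoxy, would bring a comparable step.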